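The source may hold more compounds than are shown below. What is called first, only, known or untested is meant among the compounds shown, and "the series" means these compounds.

Compound 1 `COC(=O)C1=C(C)N=C(C)/C(=C(\O)OC)C1c1cc(Cl)cc(Cl)c1` was tested in a functional assay (muscle tissue) with Cavia porcellus as the target (on this read-out lower numbers stand for an effect already at smaller amounts and higher numbers for an effect only at larger amounts of compound), where compound 1 gives 93.3 nM. Among the three numbers shown, this is the second highest. Compound 3 `COC(=O)C1=C(C)N=C(C)/C(=C(\O)OC)C1c1cc([N+](=O)[O-])ccc1O` gives 100 nM in this assay, which lies within the scatter of the number for compound 1, so the two cannot be told apart. Compound 2 `COC(=O)C1=C(C)N=C(C)/C(=C(/O)OC)C1c1cccc(Cl)c1` gives 15.9 nM, a clearly lower number, beyond the scatter. Compound 4 `COC(=O)C1=C(C)N=C(C)/C(=C(\O)OC)C1c1ccc(C#N)cc1` has not yet been measured. It differs from compound 1 in one place: 4-cyanophenyl in place of 3,5-dichlorophenyl on a saturated ring carbon. Within the data shown here, no measured pair shows a change of this kind, so there is no step to lean on. The step of a 1.1-fold higher number from compound 1 to compound 4 (0.03 log units; within the scatter) is expected to be none beyond the scatter. Compound 4 is therefore estimated at 100 nM, with a range from 30 nM to 330 nM.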

Compound 4, half-maximal effective concentration: 3470 nM
Compound 4: the middle estimate sits 35-fold (1.54 log units) below what was measured; the measured number lies above the stated range.
By their numbers in this assay, from the lowest: compound 2; then compounds 1 and 3 (each within the scatter of the next); then compound 4.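

Putting 4-cyanophenyl in place of 3,5-dichlorophenyl on this saturated ring carbon gives a 37-fold higher number from compound 1 to compound 4 (1.57 log units; beyond the scatter) in this assay with the rest of the molecule unchanged. The group at this position can therefore shift the read-out strongly, even though both groups have the same count of heavy atoms and one aromatic ring. Nothing shown here gives a reason for this large step.

This single change removes both chlorines and adds a nitrile, so it cannot show which part of the change matters. From the compounds shown here alone, how a plain phenyl or a 4-aminophenyl group would behave here remains open.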